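This account rests on a few compounds, and the source may have more. Where it says the series, first, only, none or still open, it means among the compounds named here.

Working notes on the series in a functional assay on MCF7 cells (Homo sapiens) for antiproliferative activity, read by MTT assay, with a stated time of 48 h; a lower number here means a stronger inhibitor, a higher number a weaker inhibitor. Compound 1 `N#CC1=C(N)Oc2c(N)cc3nc4ccccc4nc3c2C12C(=O)N(Cc1cnnn1-c1ccc(F)cc1)c1ccccc12` gives only a limit, > 50000 nM. Compound 2 `N#CC1=C(N)Oc2c(N)cc3nc4ccccc4nc3c2C12C(=O)N(Cc1cnnn1-c1ccc(Cl)cc1)c1ccccc12` likewise gives only a limit, > 50000 nM. Going by the values given here, compound 3 `N#CC1=C(N)Oc2c(N)cc3nc4ccccc4nc3c2C12C(=O)N(Cc1cnnn1-c1cccc(C(F)(F)F)c1)c1ccccc12` gives 31600 nM, the only number among the three; the steps of an at least 1.5-fold lower number from compound 1 to compound 3 (0.19 log units; that floor lies within the scatter) and an at least 1.5-fold lower number from compound 2 to compound 3 (0.19 log units; that floor lies within the scatter) are floors only because of the limit of > 50000 nM in this assay, at which 2 of the 3 values shown sit, and both floors lie within the scatter.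

Compound 4 `COc1ccc(-n2nncc2CN2C(=O)C3(C(C#N)=C(N)Oc4c(N)cc5nc6ccccc6nc5c43)c3ccccc32)cc1` differs by 4-methoxyphenyl in place of 3-(trifluoromethyl)phenyl on an aromatic nitrogen. Among the compounds with values here, no measured step covers a methoxyphenyl group, and the two measured steps, both into compound 3, are floors within the scatter, so no step beyond the scatter is expected in this assay in either direction, with a fair chance that compound 4 again returns only a limit. Compound 4 is expected at 40000 nM, within 12000 nM to 120000 nM. The expected step is a 1.3-fold higher number from compound 3 to compound 4 (0.10 log units; within the scatter).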

Compound 4, half-maximal inhibitory concentration: > 50000 nM
Compound 4: no number, only a limit; the forecaster's own chance of this, stated with the estimate: 50%; middle value at least 1.2-fold (0.09 log units) from the limit.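

In this assay, compound 4 gives only a limit, > 50000 nM. Going by these compounds alone, its 4-methoxyphenyl group thus joins 4-fluorophenyl and 4-chlorophenyl at the limit, and compound 3, with 3-(trifluoromethyl)phenyl, is the exception, though the only reading available is an at least 1.5-fold higher number from compound 3 to compound 4 (0.19 log units; that floor lies within the scatter). The steps from compound 1 and from compound 2 to compound 4 cannot be read, because each joins two limits: the limit of > 50000 nM in this assay, at which 3 of the 4 values shown sit.

From the compounds shown here alone, whether any group on this phenyl ring gives a step beyond the scatter remains open. An amine, a carboxylic acid or a longer chain in place of methoxy would test this.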